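Ethyl to propyl chain on the bromo congener

A few compounds are considered here, and "the series" means these few. Any claim that something is new, unique, unknown or untested is made for them only; others in the source may bear on it.

Compound 3 `CCn1c(/N=C/c2ccc(Br)cc2)c(C#N)sc1=S` gives 0.00074 nM in an assay on HEK293 cells for displacement of a labelled ligand from adenosine receptor A1 (Homo sapiens), read by scintillation counting, with a stated time of 60 min (on this read-out lower numbers stand for stronger inhibition and higher numbers for weaker inhibition), the lowest of the three numbers; compound 2 `CCCn1c(/N=C/c2ccc(Cl)cc2)c(C#N)sc1=S` gives 2.32 nM and compound 1 `CCCn1c(/N=C/c2ccc(F)cc2)c(C#N)sc1=S` gives 102 nM. Among the compounds with values here, the one step resolved so far, a 44-fold lower number from compound 1 to compound 2 (1.64 log units; beyond the scatter), concerns chloro in place of fluoro and does not touch the chain. Compound 4 `CCCn1c(/N=C/c2ccc(Br)cc2)c(C#N)sc1=S` differs from compound 3 by methyl in place of hydrogen on a saturated chain carbon, two bonds along the chain from an aromatic nitrogen, read one bond further out as ethyl to propyl. Within the data shown here, no measured pair isolates this change: compounds 1 and 2 carry the propyl chain but differ from compound 3 in the halogen as well, so nothing separates the two effects. Among the measured compounds shown here, with no bearing step, the expected step is a 2.7-fold higher number from compound 3 to compound 4 (0.43 log units; beyond the scatter), not beyond the scatter, with a wide range. Compound 4 is expected to give 0.002 nM, between 0.0002 nM and 0.05 nM.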

Compound 4, inhibition constant: 607 nM
For compound 4 the middle estimate is 300000-fold (5.48 log units) below the measured one, outside the stated range (above it).
By their numbers in this assay, from the lowest: compound 3; then compound 2; then compound 1; then compound 4.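

In this assay the chain at this position is far from neutral on the bromo congener, with ethyl to propyl giving an 820000-fold higher number from compound 3 to compound 4 (5.91 log units; beyond the scatter) as the largest step in the series. With the propyl chain held, the halogen order does not run in one direction: chloro stands lowest, and bromo gives both a 260-fold higher number from compound 2 to compound 4 (2.42 log units; beyond the scatter) and a 6.0-fold higher number from compound 1 to compound 4 (0.77 log units; beyond the scatter) as its steps upward. No measurement shown accounts for the size of these steps.

Going by these compounds, whether the ethyl advantage also holds for the chloro and fluoro congeners remains open. So does the response to a methyl or butyl chain at this position.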